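The source may hold more compounds than are shown below. What is called first, only, known or untested is meant among the compounds shown, and "the series" means these compounds.

In an assay on membranes from HeLa cells for displacement of a labelled ligand from adenosine receptor A3 (Homo sapiens), read by scintillation counting, with a stated time of 180 min, tested at 1 uM (on this read-out lower numbers stand for less inhibition and higher numbers for more inhibition at the one concentration tested (going by the name of the read-out)), compound 2 `COC(=O)C1=C(C)NC(=S)NC1c1cccs1` gives 1%. Compound 1 `COC(=O)C1=C(C)NC(=S)NC1c1ccoc1` gives 3% and compound 3 `CC1=C(C(=O)OC(C)(C)C)C(c2cccs2)NC(=S)N1` gives 22%, so compound 2 has the lowest of the three numbers shown, though its gap to compound 1 lies within the scatter and only its gap to compound 3 lies beyond it. Compound 4 `COC(=O)C1=C(C)NC(=S)NC1c1ccsc1` differs from compound 2 in one place: thiophen-3-yl in place of thiophen-2-yl on a saturated ring carbon. Among the measured compounds shown here, the one measured step that changes the group on that same saturated ring carbon, a number 2 percentage points lower from compound 1 to compound 2 (within the scatter), stayed within the scatter. The other step, a number 21 percentage points higher from compound 2 to compound 3 (beyond the scatter), concerns the ester and does not bear on this change. The expected step is therefore a number 4 percentage points higher from compound 2 to compound 4 (within the scatter), nothing beyond the scatter. Compound 4 is estimated at 5%, between 0% and 16%.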

Compound 4, a percentage reported as inhibition, at one concentration (the size of the read-out at that concentration, not a potency): 3%
The estimate for compound 4 lay 2 percentage points above the measured number; the range from low to high includes it.
By their numbers in this assay, from the lowest: compounds 2, 1 and 4 (each within the scatter of the next); then compound 3.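

In this assay, the change to thiophen-3-yl on the saturated ring carbon gives a number 2 percentage points higher from compound 2 to compound 4 (within the scatter), and the same group in place of furan-3-yl gives no change at the digits printed from compound 1 to compound 4 (within the scatter). The three five-membered aromatic rings at this position therefore cannot be told apart here, including the two ways of attaching thiophene. No measurement shown explains this sameness. Going by these compounds, whether a phenyl ring or a longer chain carrying an amine on that carbon would change the number stays open. So does whether thiophen-3-yl would behave like thiophen-2-yl alongside the tert-butyl ester of compound 3.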